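The compounds below may be only part of what the source reports. "The series", "measured", "known", "first", "only" and "open" are said of these compounds alone.

Three compounds from the series share one core and have been run in an assay on membranes from HeLa cells for displacement of a labelled ligand from adenosine receptor A3 (Homo sapiens), read by scintillation counting, with a stated time of 180 min, tested at 1 uM; on this read-out higher numbers stand for more inhibition at the one concentration tested (going by the name of the read-out) and lower numbers for less inhibition. Compound 1 `CCCOC(=O)C1=C(C)NC(=O)NC1c1cccs1` gives 32%. Within the data shown here, compound 2 `CC1=C(C(=O)CC(C)C)C(c2cccs2)NC(=O)N1` gives 18%; the only single-point step recorded, a number 14 percentage points lower from compound 1 to compound 2 (beyond the scatter), concerns isobutyl in place of propoxy on a carbonyl carbon. Compound 3 `CCC(CC)OC(=O)C1=C(C)NC(=O)NC1c1ccoc1` gives 5%, the lowest of the three numbers, with compound 2 nearest above it and compound 1 furthest.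

Compound 4 `CCC(CC)OC(=O)C1=C(C)NC(=O)NC1c1cccs1` differs from compound 3 in one place: thiophen-2-yl in place of furan-3-yl on a saturated ring carbon. Among the measured compounds shown here, no measured step covers this ring exchange, so the step from compound 1 to compound 2 offers no direct guide. What can be said is that compound 1 carries the same thiophen-2-yl ring as compound 4 but a different ester. In this assay compound 1 gives 32%, while compound 3 with the furan-3-yl ring gives 5%. On that comparison a rise is expected, though compounds 1 and 3 also differ in the ester, so the size is uncertain. Compound 4 is therefore estimated at 20%, within 5% to 38%, a step of a number 15 percentage points higher from compound 3 to compound 4 (beyond the scatter) expected.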

Compound 4, a percentage reported as inhibition, at one concentration (the size of the read-out at that concentration, not a potency): 1%
Beside the measured number, compound 4's estimate is 19 percentage points above it; the measured number lies below the stated range.
By their numbers in this assay, from the lowest: compounds 4 and 3 (each within the scatter of the next); then compound 2; then compound 1.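

In this assay, thiophen-2-yl in place of furan-3-yl on the saturated ring carbon gives a number 4 percentage points lower from compound 3 to compound 4 (within the scatter), so with the (pentan-3-yl)oxy ester present this ring exchange leaves no change beyond the scatter. With the thiophen-2-yl ring held fixed, the group on the carbonyl carbon now gives steps beyond the scatter: (pentan-3-yl)oxy in place of isobutyl gives a number 17 percentage points lower from compound 2 to compound 4 (beyond the scatter), and ethyl in place of hydrogen on the chain carbon bound to the oxygen gives a number 31 percentage points lower from compound 1 to compound 4 (beyond the scatter). No evidence is available to explain any of these steps.

On these data alone, whether the ring exchange would also stay within the scatter alongside the propoxy ester remains open. Also open, as far as these compounds go, is what a phenyl ring on the saturated ring carbon, or an ethoxy group on the carbonyl carbon, would give.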